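The compounds below may be only part of what the source reports. "The series", "measured", "known", "first", "only" and "open" are said of these compounds alone.

Compound 3 `CC(C)=CCOc1ccc2c(c1)OC(c1ccc(C)cc1C)CC2=O` is one of three compounds sharing a core; in a functional assay (a lower number here means a stronger inhibitor, a higher number a weaker inhibitor), compound 3 gives 8260 nM, the highest of the three numbers, although both steps leading to it stay within the scatter: a 1.6-fold higher number from compound 1 to compound 3 (0.20 log units; within the scatter) and a 1.9-fold higher number from compound 2 to compound 3 (0.27 log units; within the scatter). Compound 1 `CC(C)=CCOc1ccc2c(c1)OC(c1ccc(Cl)cc1Cl)CC2=O` gives 5260 nM, and compound 2 `CC(C)=CCOc1ccc2c(c1)OC(c1ccc(C)cc1)CC2=O` gives 4440 nM; the step of a 1.2-fold lower number from compound 1 to compound 2 (0.07 log units; within the scatter) also stays within the scatter. Compound 4 `CC(C)=CCOc1cc(O)c2c(c1)OC(c1ccc(C)cc1C)CC2=O` differs from compound 3 by hydroxy in place of hydrogen on an aromatic carbon. All three measured steps alter only the group on the saturated ring carbon, so none bears on a hydroxy entering the core itself. The step expected here is estimated as a 1.0-fold lower number from compound 3 to compound 4 (0.01 log units; within the scatter), with no shift beyond the scatter expected. Compound 4 is therefore expected to give about 8000 nM, within 3000 nM to 21000 nM.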

Compound 4, half-maximal inhibitory concentration: 6380 nM
Compound 4: middle estimate off by 1.3-fold (0.10 log units), on the high side, and the stated range covers the measured number.
By their numbers in this assay, from the lowest: compounds 2, 1, 4 and 3 (each within the scatter of the next).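

In this assay, hydroxy in place of hydrogen on the aromatic carbon ortho to a fused ring gives a 1.3-fold lower number from compound 3 to compound 4 (0.11 log units; within the scatter) and so stays within the scatter. Within the data shown here, this is the first measured change on the shared core itself rather than on the group at the saturated ring carbon, and at this position it brings no shift beyond the scatter. Nothing available speaks to the reason for this result. On these data alone, whether a methoxy or an amine at this same carbon would also stay within the scatter remains open. Also open, as far as these compounds go, is whether hydroxy would give a similar step alongside the 4-methylphenyl group of compound 2.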